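A few compounds are considered here, and "the series" means these few. Any claim that something is new, unique, unknown or untested is made for them only; others in the source may bear on it.

Compound 3 `C[C@@H](NC(=O)Nc1ccc(F)cc1)c1ccccc1` gives 96% in an ADME assay on the whole organism with Oryza sativa as the target, tested at 1 uM (on this read-out higher numbers stand for a weaker effect at the one concentration tested and lower numbers for a stronger effect), the lowest of the three numbers, though its gaps to the others stay within the scatter: compound 1 `CCCCCc1ccc(NC(=O)N[C@H](C)c2ccccc2)cc1` gives 101% and compound 2 `CCCCCCc1ccc(NC(=O)N[C@H](C)c2ccccc2)cc1` gives 101%. Compound 4 `C[C@@H](NC(=O)Nc1ccc(I)cc1)c1ccccc1` is not yet measured; it differs from compound 3 by iodo in place of fluoro on an aromatic carbon. Within the data shown here, the steps that bear on this are the two that also change the group at that ring position, a number 5 percentage points lower from compound 1 to compound 3 (within the scatter) and a number 5 percentage points lower from compound 2 to compound 3 (within the scatter), both small. Exchanging one halogen for another there is therefore expected to give no step beyond the scatter, a number 2 percentage points higher from compound 3 to compound 4 (within the scatter). For compound 4 the estimate is 98%, with a range from 88% to 108%.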

Compound 4, a percentage reported as activity, at one concentration (the size of the read-out at that concentration, not a potency): 91%
Compound 4: middle estimate off by 7 percentage points, on the high side, and the stated range covers the measured number.
By their numbers in this assay, from the lowest: compounds 4, 3, 1 and 2 (each within the scatter of the next).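

In this assay, iodo in place of fluoro on an aromatic carbon para to a large group gives a number 5 percentage points lower from compound 3 to compound 4 (within the scatter), so this exchange of one halogen for another stays inside the scatter at this position. Iodo in place of hexyl gives a number 10 percentage points lower from compound 2 to compound 4 (within the scatter) and iodo in place of pentyl gives a number 10 percentage points lower from compound 1 to compound 4 (within the scatter), so the four groups at this position are not told apart by this read-out. Nothing available here accounts for these numbers. Going by these compounds, it remains open whether any other group at this position, such as an amine or a carboxylic acid, would give a step beyond the scatter.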